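Aryl versus cyclohexyl amides at the dopamine D4 receptor

The source may report more compounds than this note shows. Statements on the series, on what has been measured and on what is new or still open speak of the compounds shown alone.

Measured compounds:
compound 1 `Cc1cc(NC(=O)CN2CCC(c3cccc[n+]3[O-])CC2)ccc1F` gives 18 nM
compound 2 `O=C(CN1CCC(c2cccc[n+]2[O-])CC1)Nc1ccc(F)cc1F` gives 103 nM
compound 3 `O=C(CN1CCC(c2cccc[n+]2[O-])CC1)NC1CCCCC1` gives 294 nM

In a functional assay on HEK293 cells for agonist activity at D(4) dopamine receptor (Homo sapiens), read by FLIPR (on this read-out higher numbers stand for an effect only at larger amounts of compound and lower numbers for an effect already at smaller amounts), compound 3 stands at the highest number of the three, with compound 2 nearest and compound 1 furthest away, so the cyclohexyl amide is the weakest agonist among the measured compounds. Compound 4 `O=C(CN1CCC(c2cccc[n+]2[O-])CC1)Nc1cc(Cl)cc(Cl)c1` has not yet been measured. The change from compound 3 to compound 4 is 3,5-dichlorophenyl in place of cyclohexyl on an amide-type nitrogen.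

Two of the measured steps bear on this change, both running in the opposite direction: an aromatic ring on the amide-type nitrogen gave way to cyclohexyl, with a 16-fold higher number from compound 1 to compound 3 (1.21 log units; beyond the scatter) and a 2.9-fold higher number from compound 2 to compound 3 (0.46 log units; beyond the scatter). Both were beyond the scatter and both raised the number. The step to compound 4 reverses that pattern, restoring an aromatic ring on the amide-type nitrogen, though with a substitution pattern not yet seen among the measured compounds. It is therefore expected to lower the number in this assay by a modest to large amount, and compound 4 is estimated at 50 nM, within a range of 10 nM to 200 nM. That estimate corresponds to an expected step of a 5.9-fold lower number from compound 3 to compound 4 (0.77 log units; beyond the scatter).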

Compound 4, half-maximal effective concentration: 160 nM
For compound 4 the middle estimate is 3.2-fold (0.51 log units) below the measured one; the range from low to high includes it.
By their numbers in this assay, from the lowest: compound 1; then compounds 2, 4 and 3 (each within the scatter of the next, the first and the last beyond it).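

In this assay, an aromatic ring on the amide-type nitrogen is not enough on its own to separate a compound from the cyclohexyl amide: putting 3,5-dichlorophenyl in place of cyclohexyl gives a 1.8-fold lower number from compound 3 to compound 4 (0.26 log units; within the scatter), so compound 4 goes against the pattern that compound 1 and compound 2 suggested. What the ring carries matters among these aryl amides, since exchanging 2,4-difluorophenyl for 3,5-dichlorophenyl gives a 1.6-fold higher number from compound 2 to compound 4 (0.19 log units; within the scatter), while exchanging 4-fluoro-3-methylphenyl for it gives an 8.9-fold higher number from compound 1 to compound 4 (0.95 log units; beyond the scatter), which leaves compound 1 as the only one of the four set apart from all the others by more than the scatter. No supporting data are available to explain this difference among the aromatic rings.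

The compounds shown leave open where a phenyl group with no substituent, a single chlorine on the ring or a methyl group without fluorine would fall in this series. They also leave open whether a benzyl group on the amide-type nitrogen would behave more like the aromatic rings or like cyclohexyl.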